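Hydroxyphenyl pyridines: swapping the pyridin-4-yl arm

A few compounds are considered here, and "the series" means these few. Any claim that something is new, unique, unknown or untested is made for them only; others in the source may bear on it.

Measured so far:
compound 1, `Oc1ccc(-c2cc(-c3ccncc3)nc(-c3ccc(Cl)cc3)c2)cc1`, "not determined" (no result reported)
compound 2, `Oc1cccc(-c2cc(-c3ccncc3)nc(-c3ccc(Cl)cc3)c2)c1`, 3330 nM

The series is assessed in a functional assay on T47D cells (Homo sapiens) for cytotoxicity, read by CCK-8 assay and cell counting, with a stated time of 2 days; a lower number here means a stronger inhibitor, a higher number a weaker inhibitor. Compound 2 gives 3330 nM. For compound 1 no single number stands: its result in this assay is recorded as "not determined" (no result reported), so the shared core with the hydroxyl moved to the other position has no figure against which a step can be set.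

Compound 3, `Oc1ccc(-c2cc(-c3ccc(Cl)cc3)nc(-c3ccsc3)c2)cc1`, has not been measured. It differs from compound 1 in one place: thiophen-3-yl in place of pyridin-4-yl on an aromatic carbon. Going by the values given here, no step between two measured compounds covers this exchange, and compound 1 itself offers no anchor, so the size of the step in this assay cannot be stated with any confidence; a shift in either direction of modest size, or none beyond the scatter, is plausible. Taking compound 2 as the only number in hand, compound 3 is expected to give roughly 4000 nM in this assay, with a range of 1000 nM to 15000 nM.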

Compound 3, half-maximal inhibitory concentration: 5490 nM
For compound 3 the middle estimate is 1.4-fold (0.14 log units) below the measured one; the range from low to high includes it.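

In this assay compound 3 gives 5490 nM and compound 1 stands as "not determined" (no result reported) so no step can be read between them. Nothing in hand bears on this result. From the compounds shown here alone, what exchanging pyridin-4-yl for thiophen-3-yl does to the value stays open.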